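Urea series on liver cells: a carboxy analogue awaits testing

A few compounds are considered here, and "the series" means these few. Any claim that something is new, unique, unknown or untested is made for them only; others in the source may bear on it.

Measured so far:
- compound 1 `CSc1ccc(NC(=O)Nc2cc(C)nc3ccccc23)cc1`: 16000 nM
- compound 2 `COC(=O)c1cccc(NC(=O)Nc2cc(C)nc3ccccc23)c1`: 23000 nM

Two ureas sharing one core have been examined in an ADME assay on HepG2 cells (Homo sapiens) for cytotoxicity, with a stated time of 72 h; on this read-out higher numbers stand for an effect only at larger amounts of compound and lower numbers for an effect already at smaller amounts. In this assay compound 1 gives 16000 nM, and compound 2 gives 23000 nM; the two numbers lie within the usual scatter of each other, so neither compound can be set apart from the other on this read-out. Both act only at large amounts of compound.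

Compound 3 `Cc1cc(NC(=O)Nc2ccc(C(=O)O)cc2)c2ccccc2n1` has not yet been tested in this assay. It differs from compound 1 in one place: carboxy in place of methylsulfanyl on an aromatic carbon. For the measured compounds named here, no step between two measured compounds bears on this change, so the expectation rests on the values of compound 1 and compound 2 alone. Compound 3 is expected to show a step of a 1.9-fold higher number from compound 1 to compound 3 (0.27 log units; within the scatter), which is small and probably not beyond the scatter. The estimate for compound 3 is 30000 nM, with a range from 12000 nM to 80000 nM.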

Compound 3, half-maximal effective concentration: > 25000 nM
Compound 3 ended at the assay's limit; the forecaster's own chance of this, stated with the estimate: 30%; the middle value lies beyond the limit too.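

In this assay compound 3 gives > 25000 nM, which is a limit of the assay and not a number. Carboxy in place of methylsulfanyl on an aromatic carbon, para to a large group, brings an at least 1.5-fold higher number from compound 1 to compound 3 (0.19 log units; that floor lies within the scatter), the first step at this position, and it does not shift the effect to smaller amounts of compound. The full size of this step cannot be read because the reading for compound 3 stops at the limit: the limit of > 25000 nM in this assay, at which 1 of the 3 values shown sits.

From the compounds shown here alone, whether the true gap between carboxy and methylsulfanyl lies within the scatter or beyond it therefore stays open. Also open, going by these compounds, is what an amine or a hydroxy group would do on the same aromatic carbon of the shared core.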